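The source may report more compounds than this note shows. Statements on the series, on what has been measured and on what is new or still open speak of the compounds shown alone.

Series notes. Going by the values given here, compound 1 `CCCCCCCC(=O)Nc1ccc2[nH]cc(C3CCN(C)CC3)c2n1` is the reference point: in an assay for binding affinity to 5-hydroxytryptamine receptor 1D (Homo sapiens), read by radioligand binding (a lower number here means a stronger inhibitor, a higher number a weaker inhibitor), compound 1 gives 110 nM, the lowest of the three numbers so far. The two other measured members, compound 2 `CN1CCC(c2c[nH]c3ccc(NC(=O)c4ccc(C#N)cc4)nc23)CC1` and compound 3 `CN1CCC(c2c[nH]c3ccc(NC(=O)c4cccs4)nc23)CC1`, carry an aromatic ring on the carbonyl carbon where compound 1 has the heptyl chain; compound 2 gives 380 nM and compound 3 gives 650 nM. Both steps away from compound 1 run the same way: a 3.5-fold higher number from compound 1 to compound 2 (0.54 log units; beyond the scatter) and a 5.9-fold higher number from compound 1 to compound 3 (0.77 log units; beyond the scatter). Between the two aromatic members the gap is a 1.7-fold higher number from compound 2 to compound 3 (0.23 log units; within the scatter), so the two rings cannot be told apart on these data.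

Compound 4 `CN1CCC(c2c[nH]c3ccc(NC(=O)c4ccncc4)nc23)CC1` is the next variant: pyridin-4-yl in place of heptyl on a carbonyl carbon. Both earlier replacements of heptyl by an aromatic ring raised the number beyond the scatter, and no measured case shows a ring matching the chain, so a modest rise is expected for compound 4 in this assay, of about the size of the two earlier steps. Compound 4 is estimated at 500 nM, within 200 nM to 1500 nM, which corresponds to an expected step of a 4.5-fold higher number from compound 1 to compound 4 (0.66 log units; beyond the scatter).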

Compound 4, inhibition constant: 420 nM
Beside the measured number, compound 4's estimate is 1.2-fold (0.08 log units) above it; low and high end bracket the measured number.
By their numbers in this assay, from the lowest: compound 1; then compounds 2, 4 and 3 (each within the scatter of the next).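

In this assay, a third aromatic ring on the carbonyl carbon, this one with a ring nitrogen, again gives a number beyond the scatter of the heptyl reference (a 3.8-fold higher number from compound 1 to compound 4 (0.58 log units; beyond the scatter)). Pyridin-4-yl cannot be told apart from the other two rings (a 1.5-fold lower number from compound 3 to compound 4 (0.19 log units; within the scatter); a 1.1-fold higher number from compound 2 to compound 4 (0.04 log units; within the scatter)), so across these three rings the hetero atom makes no readable difference, and the gap to heptyl is the feature that holds for all three. Nothing at hand gives a reason for that gap.

Open, going by these compounds, is whether the lower number of compound 1 belongs to the heptyl chain itself or to non-aromatic groups generally, such as cyclohexyl. A shorter or longer chain on the carbonyl carbon, or a chain ending in an amine or a carboxylic acid, would test this.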